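Swapping ethyl for phenyl on the shared core

A few compounds are considered here, and "the series" means these few. Any claim that something is new, unique, unknown or untested is made for them only; others in the source may bear on it.

Compound 1 `COc1cccc(-c2nn[nH]n2)c1`: > 3400000 nM (a limit)
Compound 2 `CCOc1cccc(-c2nn[nH]n2)c1`: 2210000 nM

Both compounds were tested in a functional assay with Ovis aries as the target, read by hemolysis, in the absence of a further agent; on this read-out lower numbers stand for an effect already at smaller amounts and higher numbers for an effect only at larger amounts of compound. Going by the values given here, compound 2 holds the only actual number so far, 2210000 nM, in this assay. Compound 1 gives no number, only a limit, described as the limit of > 3400000 nM in this assay, at which 1 of the 2 values shown sits.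

Compound 3 `c1ccc(Oc2cccc(-c3nn[nH]n3)c2)cc1` has not yet been measured. It differs from compound 2 in one place: phenyl in place of ethyl on an oxygen on an aromatic ring. Among the compounds with values here, only one measured step bears on this change, and only loosely: an at least 1.5-fold lower number from compound 1 to compound 2 (0.18 log units; that floor lies within the scatter), with methyl in place of hydrogen on a saturated chain carbon bound to an oxygen on an aromatic ring. That step is a floor lying within the scatter, so it offers only a weak hint of direction. A moderately lower number is therefore expected in this assay, and the expected change is a 2.5-fold lower number from compound 2 to compound 3 (0.39 log units; beyond the scatter). Compound 3 is estimated at 900000 nM, with an expected range of 250000 nM to 3000000 nM.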

Compound 3, half-maximal effective concentration: 954000 nM
The estimate for compound 3 lay 1.1-fold (0.03 log units) below the measured number; the range from low to high includes it.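

In this assay, going by these compounds alone, phenyl in place of ethyl on the oxygen gives the first step at this position with a firm size beyond the scatter, where the earlier pair offered only a floor within it: a 2.3-fold lower number from compound 2 to compound 3 (0.36 log units; beyond the scatter). Set against the methyl compound, the same position reads an at least 3.5-fold lower number from compound 1 to compound 3 (0.55 log units; beyond the scatter), and this figure is a floor rather than a size. Compound 1 carries only a limit in this assay: the limit of > 3400000 nM in this assay, at which 1 of the 3 values shown sits.

With only methyl, ethyl and phenyl on this oxygen, the compounds shown cannot tell whether the lower number belongs to the aromatic ring itself or simply goes with more heavy atoms on the oxygen, a question on which a longer chain such as butyl, or a benzyl group, would bear. They also leave open whether a chlorine atom or a methoxy group on the new phenyl, or an amine or a carboxylic acid in its place, would move the number further in this assay.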